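The source may hold more compounds than are shown below. What is called first, only, known or untested is meant among the compounds shown, and "the series" means these compounds.

Measured compounds:
compound 1 `Nc1cc(N)c2nc(-c3ccccc3)c(Oc3ccc(Cl)c(Cl)c3)nc2c1` — 17000 nM
compound 2 `Nc1cc(N)c2nc(-c3ccccc3)c(NCc3ccc(Cl)c(Cl)c3)nc2c1` — 15800 nM
compound 3 `CCOC(=O)[C@H](CCC(=O)O)NC(=O)c1ccc(Sc2nc3cc(N)cc(N)c3nc2-c2ccccc2)cc1` — 15500 nM

In a functional assay on HOP-62 cells (Homo sapiens) for inhibition, read by sulforhodamine B assay, with a stated time of 48 h (on this read-out higher numbers stand for weaker inhibition of growth and lower numbers for stronger inhibition of growth), compound 1 gives the highest of the three numbers, yet compound 2 and compound 3 both fall within the scatter of it, so the three values show no order among themselves. Compound 4 `Nc1cc(N)c2nc(-c3ccccc3)c(Oc3ccc(F)cc3)nc2c1` differs from compound 1 as follows: 4-fluorophenyl in place of 3,4-dichlorophenyl on an oxygen on an aromatic ring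

For the measured compounds named here, no step between measured compounds covers this change. Since the measured values all sit close together across quite different groups on the shared core, no step beyond the scatter is expected in this assay for this change either. Compound 4 is therefore expected to give 18000 nM, with a range from 8000 nM to 45000 nM. The expected step of a 1.1-fold higher number from compound 1 to compound 4 (0.02 log units; within the scatter) stays within the scatter.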

Compound 4, concentration for 50% growth inhibition: 21400 nM
Compound 4: the middle estimate sits 1.2-fold (0.08 log units) below what was measured; low and high end bracket the measured number.
By their numbers in this assay, from the lowest: compounds 3, 2, 1 and 4 (each within the scatter of the next).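

In this assay, for the compounds shown here, the step of a 1.3-fold higher number from compound 1 to compound 4 (0.10 log units; within the scatter) stays within the scatter, the first reading of a change on the aryl group at this oxygen. On this evidence, 4-fluorophenyl and 3,4-dichlorophenyl cannot be told apart at this position. No measured data bear on this result.

Whether any group on this oxygen separates from the others remains open, since only these two aryl groups are shown there. A phenyl ring carrying a morpholine or a carboxylic acid, or a longer alkyl chain in place of the aryl group, could test this.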